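Shortening the piperazine substituent to methyl in a dithiocarbamate series

A few compounds are considered here, and "the series" means these few. Any claim that something is new, unique, unknown or untested is made for them only; others in the source may bear on it.

Measured so far, in a functional assay on MGC-803 cells (Homo sapiens) for antiproliferative activity, read by CCK-8 assay, with a stated time of 72 h, tested at 8 uM; a higher number here means a stronger effect of the compound at the concentration tested, a lower number a weaker effect:
compound 1 `Nc1ccccc1NC(=O)c1ccc(CSC(=S)N2CCN(c3ccc(Cl)cc3)CC2)cc1`: 17.2%
compound 2 `CC1CCCCN1C(=S)SCc1ccc(C(=O)Nc2ccccc2N)cc1`: 86.9%
compound 3 `Nc1ccccc1NC(=O)c1ccc(CSC(=S)N2CCN(Cc3ccncc3)CC2)cc1`: 79.3%

Among these three numbers compound 3 stands second highest. Its nearest neighbour is compound 2, whose value lies within the scatter of it, so no order between the two can be claimed; its furthest is compound 1, which lies well below it. The only step that joins two of these compounds in one place is a number 62.1 percentage points higher from compound 1 to compound 3 (beyond the scatter), a large gain.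

Compound 4 `CN1CCN(C(=S)SCc2ccc(C(=O)Nc3ccccc3N)cc2)CC1` differs from compound 3 by hydrogen in place of pyridin-4-yl on a saturated chain carbon bound to an amine nitrogen in a ring; cut one bond further out, the change reads (pyridin-4-yl)methyl to methyl. Going by the values given here, no measured step removes a group in this way. What the data do show is that two different small or heterocyclic substituents on this ring nitrogen, in compound 2 and compound 3, both give high inhibition, while only the 4-chlorophenyl of compound 1 gives a low one. Compound 4 is therefore expected to stay in the high range, with the step of a number 3.3 percentage points lower from compound 3 to compound 4 (within the scatter) expected to lie within the scatter. The estimate for compound 4 is 76%, between 52% and 92%.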

Compound 4, a percentage reported as inhibition, at one concentration (the size of the read-out at that concentration, not a potency): 84.4%
Estimate against measurement, compound 4: 8.4 percentage points below, and the stated range covers the measured number.
By their numbers in this assay, from the lowest: compound 1; then compounds 3, 4 and 2 (each within the scatter of the next).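

In this assay, the step of a number 5.1 percentage points higher from compound 3 to compound 4 (within the scatter) shows that, on this saturated chain carbon bound to an amine nitrogen in a ring, the pyridin-4-yl can give way to hydrogen with no readable difference. The step of a number 67.2 percentage points higher from compound 1 to compound 4 (beyond the scatter) gives a second large gap to compound 1, now from a plain methyl, so the low value remains with 4-chlorophenyl alone among these compounds. The step of a number 2.5 percentage points lower from compound 2 to compound 4 (within the scatter) for 4-methylpiperazin-1-yl in place of 2-methylpiperidin-1-yl leaves these two groups on the thiocarbonyl carbon indistinguishable at this single concentration. Nothing available explains any of these steps.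

The compounds shown leave open whether an unsubstituted phenyl or a 4-chlorobenzyl on the ring nitrogen would fall with compound 1 or with compound 4. They also cannot separate the chlorine from the directly attached aromatic ring as the feature that goes with the low value.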